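The source may report more compounds than this note shows. Statements on the series, on what has been measured and on what is new or still open speak of the compounds shown alone.

Compound 1, `CCc1cc2c(cc1C(=O)c1ccc(C(=O)O)cc1)C(C)(C)CCC2(C)C`: in an assay on CV-1 cells with retinoic acid receptor alpha (Homo sapiens) as the target (on this read-out higher numbers stand for an effect only at larger amounts of compound and lower numbers for an effect already at smaller amounts), compound 1 gives > 10000 nM, which is a limit of the assay.
Compound 2, `CCCc1cc2c(cc1C(=O)c1ccc(C(=O)O)cc1)C(C)(C)CCC2(C)C`: in this assay compound 2 gives > 10000 nM, again a limit of the assay.

Among the measured compounds shown here, compound 2 therefore stands only at a limit, not at a number, and the same holds for the one further value shown, as the limit of > 10000 nM in this assay, at which 2 of the 2 values shown sit, states. The step that the two limits leave unreadable from compound 1 to compound 2, methyl in place of hydrogen on a saturated chain carbon two bonds along the chain from an aromatic carbon, is for this reason unreadable in size.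

Compound 3, `CC1(C)CCC(C)(C)c2cc(C(=O)c3ccc(C(=O)O)cc3)c(F)cc21`, differs from compound 2 by fluoro in place of propyl on an aromatic carbon. For the measured compounds named here, no measured step gives a readable size that bears on this change. Compound 3 is therefore estimated to lie near the limit as well, with a step of an at least 1.2-fold lower number from compound 2 to compound 3 (0.09 log units; that floor lies within the scatter) that is expected to stay within the scatter. The estimate for compound 3 in this assay is 8000 nM, within a range from 1500 nM to 30000 nM.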

Compound 3, half-maximal effective concentration: 2860 nM
Estimate against measurement, compound 3: 2.8-fold (0.45 log units) above, within the range that was stated.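

In this assay, among the compounds shown here, this position gives a readable number for the first time with compound 3, whereas the ethyl and propyl compounds left the step between them unreadable. Fluoro in place of propyl on an aromatic carbon gives an at least 3.4-fold lower number from compound 2 to compound 3 (0.54 log units; beyond the scatter), and fluoro in place of ethyl at that same position gives an at least 3.4-fold lower number from compound 1 to compound 3 (0.54 log units; beyond the scatter), both beyond the scatter. These sizes are only floors, because compound 1 and compound 2 both sit at a limit of the assay: the limit of > 10000 nM in this assay, at which 2 of the 3 values shown sit.

The compounds shown do not tell whether fluoro itself or the absence of an alkyl chain goes with the lower number. Hydrogen, methyl, chloro or an amine at this position would bear on that question.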